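Isoquinolinyl urea compound 4: expected gain over compound 1

The source may report more compounds than this note shows. Statements on the series, on what has been measured and on what is new or still open speak of the compounds shown alone.

Measured compounds:
compound 1 `CN(C)C1(Cc2ccccc2)CCN(c2cc(C(F)(F)F)ccc2CNC(=O)Nc2ccc(NS(C)(=O)=O)c(F)c2)CC1`, 1160 nM
compound 2 `CN(C)C1(Cc2ccccc2)CCN(c2cc(C(F)(F)F)ccc2CNC(=O)Nc2cccc3c2CC(O)CC3)CC1`, 0.95 nM
compound 3 `CN(C)C1(Cc2ccccc2)CCN(c2cc(C(F)(F)F)ccc2CNC(=O)Nc2ccc3c(c2)OCC3)CC1`, 41.4 nM

In an assay on CHO cells for displacement of a labelled ligand from transient receptor potential cation channel subfamily V member 1 (Homo sapiens), read by scintillation counting, with a stated time of 60 min (a lower number here means a stronger inhibitor, a higher number a weaker inhibitor), compound 1 gives the highest number of the three, and both other compounds are beyond the scatter from it. The unmeasured compound 4 `CN(C)C1(Cc2ccccc2)CCN(c2cc(C(F)(F)F)ccc2CNC(=O)Nc2ccc3ccncc3c2)CC1` differs from compound 1 in one place: isoquinolin-7-yl in place of 3-fluoro-4-(methanesulfonamido)phenyl on an amide-type nitrogen. The two measured steps from compound 1 both swap the same group for a bicyclic ring system and both fall sharply: a 1200-fold lower number from compound 1 to compound 2 (3.09 log units; beyond the scatter) and a 28-fold lower number from compound 1 to compound 3 (1.45 log units; beyond the scatter). The step between those two replacements, a 44-fold higher number from compound 2 to compound 3 (1.64 log units; beyond the scatter), shows how much the choice of bicycle matters. Compound 4 is therefore expected to give a large fall, a 58-fold lower number from compound 1 to compound 4 (1.76 log units; beyond the scatter), and its estimated value in this assay is 20 nM, from 3 nM to 150 nM.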

Compound 4, inhibition constant: 7.33 nM
Compound 4: the middle estimate sits 2.7-fold (0.44 log units) above what was measured; the range from low to high includes it.
By their numbers in this assay, from the lowest: compound 2; then compound 4; then compound 3; then compound 1.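

In this assay a replacement with two aromatic rings, one holding a ring nitrogen, also brings a large fall a 160-fold lower number from compound 1 to compound 4 (2.20 log units; beyond the scatter) and so shows that the gain at this amide-type nitrogen does not need a non-aromatic ring. Isoquinolin-7-yl also falls between the two earlier replacements: a 5.6-fold lower number from compound 3 to compound 4 (0.75 log units; beyond the scatter) and a 7.7-fold higher number from compound 2 to compound 4 (0.89 log units; beyond the scatter) are both modest but beyond the scatter. Like compound 3, compound 4 has no hydroxy group on this bicycle, yet compound 2, which has one, still gives the lowest number.

No measurement here explains these differences. From the compounds shown here alone, whether isoquinolin-5-yl, or an amine on the isoquinoline, would match compound 2 remains open.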